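A few compounds are considered here, and "the series" means these few. Any claim that something is new, unique, unknown or untested is made for them only; others in the source may bear on it.

Compound 1 `CC(=O)OCCc1c(C)nc(Cl)nc1Cl` is the anchor of the series. In a functional assay on SW-620 cells (Homo sapiens) for antiproliferative activity, read by MTT assay, with a stated time of 24 h (on this read-out lower numbers stand for stronger inhibition and higher numbers for weaker inhibition), compound 1 gives > 100000 nM, which is a limit of the assay and not a number. Compound 2 `COc1nc(Cl)nc(C)c1CCOC(C)=O` differs from it by a methoxy in place of chloro on an aromatic carbon. In this assay compound 2 gives > 100000 nM, again a limit of the assay. The step that the two limits leave unreadable from compound 1 to compound 2 is therefore not readable in size, since both values sit at the limit of > 100000 nM in this assay, at which 2 of the 2 values shown sit. Compound 1 thus stands at the limit, with no measured number anywhere in the series.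

Compound 3 `Cc1nc(Cl)nc(Cl)c1CCCl` differs from compound 1 by chloro in place of acetoxy on a saturated chain carbon, two bonds along the chain from an aromatic carbon. Going by the values given here, no measured step bears on this change; the only measured step is unreadable. Nothing in the data supports a step beyond the scatter, so the expectation for compound 3 is a number no higher from compound 1 to compound 3 (the limit leaves the size open). Compound 3 is estimated at 100000 nM, within 30000 nM to 300000 nM, most likely reported again as a limit.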

Compound 3, half-maximal inhibitory concentration: 400 nM
Compound 3: the middle estimate sits 250-fold (2.40 log units) above what was measured; measured number outside the range, below it.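

At the saturated chain carbon, two bonds along the chain from an aromatic carbon, chloro in place of acetoxy gives an at least 250-fold lower number from compound 1 to compound 3 (2.39 log units; beyond the scatter) in this assay. Going by these compounds alone, this is the first readable step and shows that the read-out responds to a change at this chain position, whereas the step from methoxy in place of chloro on an aromatic carbon cannot be read. The true size of the new step remains open because compound 1 is a limit of the assay: the limit of > 100000 nM in this assay, at which 2 of the 3 values shown sit.

The compounds shown do not tell how a hydroxyl, an amine or a longer chain would read at this position, so the effect of chloro cannot be separated from the loss of acetoxy. They also do not tell whether methoxy in place of chloro on an aromatic carbon would change the number once chloro stands on the chain.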